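Dichlorophenyl variant of a piperazine imide series

The source may hold more compounds than are shown below. What is called first, only, known or untested is meant among the compounds shown, and "the series" means these compounds.

Going by the values given here, compound 1 `CC1CC(=O)N(CC(=O)N2CCN(c3ccccc3)CC2)C1=O` is one of three compounds measured in a functional assay on the whole organism (strain CD1) with Mus musculus as the target, with a stated time of 0.5 h; on this read-out higher numbers stand for an effect only at larger amounts of compound and lower numbers for an effect already at smaller amounts. In this assay compound 1 gives 300 mg/kg; compound 3 `CC1CC(=O)N(CC(=O)N2CCN(c3cccc(C(F)(F)F)c3)CC2)C1=O` gives 300 mg/kg, and the step of no change at the digits printed from compound 1 to compound 3 (within the scatter) lies within the scatter, so the two stand level as the highest pair of the three. Compound 2 `CCC1(C)CC(=O)N(CC(=O)N2CCN(c3ccc(Cl)cc3)CC2)C1=O` differs from compound 1 in two places at once, and compound 2 gives 100 mg/kg, a number that is lower by more than the scatter.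

The next compound, compound 4 `CC1CC(=O)N(CC(=O)N2CCN(c3ccc(Cl)c(Cl)c3)CC2)C1=O`, differs from compound 1 in one place: 3,4-dichlorophenyl in place of phenyl on an amine nitrogen in a ring. Among the compounds with values here, the only single step measured on the ring attached to the amine nitrogen is the one from compound 1 to compound 3, and it brought no change beyond the scatter. The lower number of compound 2 suggests that a halogen on that ring may go with a smaller dose, but compound 2 also carries a changed core, so that reading is uncertain. Compound 4 is therefore expected to give 200 mg/kg, in the range 100 mg/kg to 300 mg/kg, which means an expected step of a 1.5-fold lower number from compound 1 to compound 4 (0.18 log units; within the scatter).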

Compound 4, minimum effective dose: 100 mg/kg
Estimate against measurement, compound 4: 2.0-fold (0.30 log units) above; low and high end bracket the measured number.
By their numbers in this assay, from the lowest: compounds 2 and 4 (each within the scatter of the next); then compounds 1 and 3 (each within the scatter of the next).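

In this assay, 3,4-dichlorophenyl in place of phenyl on an amine nitrogen in a ring gives a 3.0-fold lower number from compound 1 to compound 4 (0.48 log units; beyond the scatter), and this is the only single change shown at this position that goes beyond the scatter. The other single change there, no change at the digits printed from compound 1 to compound 3 (within the scatter), stayed within the scatter, so the read-out at this position does not respond alike to every group placed on the phenyl. No measurement shown accounts for the difference between these two replacements.

The compounds shown leave open whether a monochlorophenyl group on the core of compound 1 would match the dichlorophenyl step; compound 2 carries its chlorine only together with a changed core. They also leave open how a methoxy group or a nitrile on that ring, or a pyridine in place of the phenyl, would read.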